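Bromo added to compound 1: an expectation

The source may report more compounds than this note shows. Statements on the series, on what has been measured and on what is new or still open speak of the compounds shown alone.

The series shares the core of compound 1 `O=C(Nc1ccc(Sc2nc3ccccc3s2)cc1)c1ccccc1`. In an assay on isolated protein for inhibition of thiosulfate sulfurtransferase (Homo sapiens), with a stated time of 60 min, in the absence of a further agent (a lower number here means a stronger inhibitor, a higher number a weaker inhibitor), compound 1 gives > 100000 nM, which is a limit of the assay and not a number. Compound 2 `O=C(Nc1ccc(Sc2nc3ccccc3s2)c(Cl)c1)c1cc(Br)ccc1O` carries further substituents; in this assay compound 2 gives > 100000 nM, again a limit. Among the compounds with values here, both values sit at the limit of > 100000 nM in this assay, at which 2 of the 2 values shown sit, so compound 1 cannot be placed above or below any other compound here, and no step between measured compounds exists.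

Compound 3 `O=C(Nc1ccc(Sc2nc3ccccc3s2)cc1)c1cccc(Br)c1` is not yet measured. It differs from compound 1 by bromo in place of hydrogen on an aromatic carbon, meta to a large group, or, read one bond further out, phenyl to 3-bromophenyl. With both measured values at the limit, no direction beyond the scatter can be supported. Compound 3 is expected at 100000 nM, between 30000 nM and 300000 nM. The step of a number no higher from compound 1 to compound 3 (the limit leaves the size open) is expected to stay within the scatter, most likely reported as a limit again.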

Compound 3, half-maximal inhibitory concentration: > 100000 nM
Compound 3 gave a limit, no number (the forecaster's own chance of this, stated with the estimate: 75%); the middle value lies on the limit itself.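

No step can be read from compound 1 to compound 3, as both stand at a limit of this assay: the limit of > 100000 nM in this assay, at which 3 of the 3 values shown sit.

The compounds shown leave open whether bromo in place of hydrogen on an aromatic carbon changes inhibition at all, and what number any compound of the series would give.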